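A few compounds are considered here, and "the series" means these few. Any claim that something is new, unique, unknown or untested is made for them only; others in the source may bear on it.

For the measured compounds named here, in a physicochemical assay for lipophilicity, at pH 7.4 (on this read-out lower numbers stand for lower lipophilicity and higher numbers for higher lipophilicity), two compounds have measured values so far. Compound 1 `O=c1ncn(Cc2ccc(F)cc2F)c2cc(F)c(Oc3ncccc3C(F)(F)F)cc12` gives 3.9, and compound 2 `O=c1ncn(Cc2c(F)cc(F)cc2F)c2ccc(Oc3cnccc3C(F)(F)F)cc12` gives 3, the lower of the two numbers, with a gap to compound 1 that lies beyond the usual scatter. Compound 3 `O=c1ncn(Cc2c(F)cc(F)cc2F)c2ccc(Oc3cccnc3C(F)(F)F)cc12` has not yet been measured. It has the same atoms as compound 2, joined differently: 2-(trifluoromethyl)pyridin-3-yl in place of 4-(trifluoromethyl)pyridin-3-yl on an oxygen on an aromatic ring. In words, 2-(trifluoromethyl)pyridin-3-yl stands in place of 4-(trifluoromethyl)pyridin-3-yl on an oxygen on an aromatic ring. Going by the values given here, no measured pair differs in one place only, so the data offer no direct precedent for this change in this assay, and the expectation is tentative. A moderate upward move is expected, estimated as a number 0.40 log units higher from compound 2 to compound 3 (beyond the scatter). For compound 3 the estimated value is 3.4, with an expected range of 3 to 3.9.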

Compound 3, distribution coefficient: 2.9
The estimate for compound 3 lay 0.50 log units above the measured number; measured number outside the range, below it.
By their numbers in this assay, from the lowest: compounds 3 and 2 (each within the scatter of the next); then compound 1.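

Putting 2-(trifluoromethyl)pyridin-3-yl in place of 4-(trifluoromethyl)pyridin-3-yl on an oxygen on an aromatic ring gives, in this assay, a number 0.10 log units lower from compound 2 to compound 3 (within the scatter). For the compounds shown here, this is the first pair that differs in one place, and it gives a direct reading for this position: rearranging the same atoms in this way leaves the read-out within the scatter. No available measurement bears on why the two groups read alike.

Still open, as far as these compounds go, is whether a different group at this position, such as a nitrile in place of the trifluoromethyl or an amine on the same ring, would shift the read-out. Also open, from the compounds shown here alone, is whether this same exchange reads alike on the rest of compound 1.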